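The source may report more compounds than this note shows. Statements on the series, on what has been measured and on what is new or still open speak of the compounds shown alone.

Measured so far:
- Compound 1, `O=c1[nH]cc(S(=O)(=O)Nc2ccccc2-c2cn(-c3ccccc3F)nn2)c(=O)[nH]1`. In an ADME assay on L02 cells (Homo sapiens) for cytotoxicity, read by MTT assay, with a stated time of 24 h (on this read-out higher numbers stand for lower toxicity in this test and lower numbers for higher toxicity in this test), compound 1 gives a value that is a limit of the assay, > 100000 nM.
- Compound 2, `O=c1[nH]cc(S(=O)(=O)Nc2ccccc2-c2cn(-c3ccc(Cl)cc3)nn2)c(=O)[nH]1`, which in this assay gives 16800 nM.
- Compound 3, `Cc1ccccc1-n1cc(-c2ccc(NS(=O)(=O)c3c[nH]c(=O)[nH]c3=O)cc2)nn1`, which in this assay is reported only as "not toxic" (no number reported).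

Compound 3 thus has no single number in this assay; its reading sits alongside (the limit of > 100000 nM in this assay, at which 1 of the 3 values shown sits), so its place among the other values cannot be set more closely than that.

Compound 4, `O=c1[nH]cc(S(=O)(=O)Nc2ccc(-c3cn(-c4cccc(Cl)c4)nn3)cc2)c(=O)[nH]1`, differs from compound 3 in one place: 3-chlorophenyl in place of 2-methylphenyl on an aromatic nitrogen. Going by the values given here, the only measured step of a similar kind is the exchange of a 2-fluorophenyl for a 4-chlorophenyl on the same aromatic nitrogen, which gave an at least 5.9-fold lower number from compound 1 to compound 2 (0.77 log units; beyond the scatter). That step swapped a small group on the attached ring for a chlorine in a different position and came out as higher toxicity, beyond the scatter. The change from compound 3 to compound 4 also brings in a chlorine in place of a small group on that ring, so a similar move toward lower numbers in this assay is expected, though compound 3 has no number to anchor it. For compound 4 the expected value in this assay is 40000 nM, within a range from 12000 nM to 100000 nM.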

Compound 4, half-maximal cytotoxic concentration: 19000 nM
Compound 4: middle estimate off by 2.1-fold (0.32 log units), on the high side; the measured number falls inside the stated range.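

In this assay compound 3 is reported as "not toxic" (no number reported) and compound 4 gives 19000 nM, so no new step can be read between these two compounds. The compounds shown leave open how far 3-chlorophenyl in place of 2-methylphenyl moves the number in this assay, and whether other groups on that aromatic nitrogen would behave alike.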